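Hydroxyalkyl Purine Analogues in a HeLa Cell Assay

The source may hold more compounds than are shown below. What is called first, only, known or untested is meant among the compounds shown, and "the series" means these compounds.

The study compares four compounds on two closely related cores. Compound 1 `CC(O)n1cnc2c(N)nc(I)nc21` and compound 2 `Nc1nc(I)nc2c1ncn2OCCO` share one core. In a functional assay on HeLa cells (Homo sapiens) for inhibition (a lower number here means a stronger inhibitor, a higher number a weaker inhibitor), compound 1 reaches only the limit of the assay, > 500000 nM. In this assay compound 2 likewise reaches only the limit, > 500000 nM. The two differ by 2-hydroxyethoxy in place of 1-hydroxyethyl on an aromatic nitrogen, and the step that the two limits leave unreadable from compound 1 to compound 2 cannot be read because of the limit of > 500000 nM in this assay, at which 3 of the 3 values shown sit.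

Compound 3 `CC(O)n1cnc2c(S)nc(F)nc21` stands on the second core; the difference between the two cores is not broken down here. In this assay compound 3 also reaches only the limit, > 500000 nM. Compound 4 `OCCOn1cnc2c(S)nc(F)nc21` has not yet been measured and differs from compound 3 by 2-hydroxyethoxy in place of 1-hydroxyethyl on an aromatic nitrogen, the same change as between compound 1 and compound 2.

Since all three measured values sit at the limit, the expected step of a number no higher from compound 3 to compound 4 (the limit leaves the size open) is no more than a placeholder. Compound 4 is accordingly expected to show 500000 nM in this assay, most likely again as a limit, with an estimated range from 150000 nM to 500000 nM.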

Compound 4, half-maximal inhibitory concentration: > 500000 nM
Compound 4 gave a limit, no number (the forecaster's own chance of this, stated with the estimate: 90%); the middle value sits exactly at the limit.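

In this assay compound 4 gives > 500000 nM as a limit of the assay, not a number. Among the compounds shown here, no step from compound 3 to compound 4 can be read, because both values sit at the same limit: the limit of > 500000 nM in this assay, at which 4 of the 4 values shown sit. The compounds shown leave open whether 2-hydroxyethoxy in place of 1-hydroxyethyl changes inhibition on either core.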